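The compounds below may be only part of what the source reports. "The series", "measured", "known", "first", "only" and "open" are said of these compounds alone.

Compound 1 `COc1ccc([C@@H]2C/C(=N/OCc3cn(-c4ccc(Cl)cc4C)nn3)c3cc(CC=C(C)C)c(OC)cc3O2)cc1` stands highest of the two numbers in a functional assay on PC-3 cells (Homo sapiens) for inhibition, read by sulforhodamine B assay, with a stated time of 48 h, tested at 50 uM (on this read-out higher numbers stand for more inhibition of growth at the one concentration tested and lower numbers for less inhibition of growth), where compound 1 gives 49%. Compound 2 `COc1ccc([C@@H]2C/C(=N/OCc3cn(-c4ccc(C(=O)c5ccccc5)cc4)nn3)c3cc(CC=C(C)C)c(OC)cc3O2)cc1` gives 40% in this assay, a number within the scatter of compound 1, so the two cannot be ordered. Compound 3 `COc1ccc([C@@H]2C/C(=N/OCc3cn(-c4cccc(CO)c4)nn3)c3cc(CC=C(C)C)c(OC)cc3O2)cc1` has not yet been measured. It differs from compound 1 in one place: 3-(hydroxymethyl)phenyl in place of 4-chloro-2-methylphenyl on an aromatic nitrogen. Among the compounds with values here, with no step between measured compounds to draw on, the expected step of a number 7 percentage points lower from compound 1 to compound 3 (within the scatter) is small, a slight fall at most, and not clearly beyond the scatter. Compound 3 is estimated at 42%, within a range from 25% to 60%.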

Compound 3, percent growth inhibition at one concentration: 34%
Estimate against measurement, compound 3: 8 percentage points above, within the range that was stated.
By their numbers in this assay, from the lowest: compounds 3, 2 and 1 (each within the scatter of the next, the first and the last beyond it).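

In this assay, the group on the aromatic nitrogen can move the read-out beyond the scatter: 3-(hydroxymethyl)phenyl in place of 4-chloro-2-methylphenyl gives a number 15 percentage points lower from compound 1 to compound 3 (beyond the scatter). The entering group has 1 hydrogen-bond donor and 1 hydrogen-bond acceptor where the leaving group has neither, but the change replaces several ring substituents at once, so no single feature can be credited. No measurement here explains the fall. From the compounds shown here alone, what stays open is whether gaining hydroxymethyl or losing chloro and methyl carries the step, and how a plain phenyl, an aminomethyl or a carboxylic acid would read in this assay.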